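The source may hold more compounds than are shown below. What is called first, only, known or untested is meant among the compounds shown, and "the series" means these compounds.

Measured so far in an ADME assay on BaF3 cells (Mus musculus) for cytotoxicity, read by CellTiter-Glo and CCK-8 assay, with a stated time of 72 h; on this read-out lower numbers stand for stronger inhibition of growth and higher numbers for weaker inhibition of growth:
compound 1 `CCC(=O)NCc1ccc(C(=O)Nc2ccc(C)c(Nc3nccc(-c4cccnc4)n3)c2)cc1` gives > 10000 nM;
compound 2 `C=CC(=O)Nc1cc(C(=O)Nc2ccc(C)c(Nc3nccc(-c4cccnc4)n3)c2)cc(C(F)(F)F)c1` gives 5460 nM.

For compound 1 the value is a limit of the assay and not a number (the limit of > 10000 nM in this assay, at which 1 of the 2 values shown sits). Compound 2 gives a number within the measured range. Compound 3 `C/C=C/C(=O)N(CCN(C)C)Cc1ccc(C(=O)Nc2ccc(C)c(Nc3nccc(-c4cccnc4)n3)c2)cc1` has not yet been measured in this assay. It differs from compound 1 in one place: (2-(dimethylamino)ethyl)((prop-1-en-1-yl)carbonyl)amino in place of propanoylamino on a saturated chain carbon bound to an aromatic carbon. Among the measured compounds shown here, no step between two measured compounds is available, so the size of this change cannot be read from a measured pair. The step of an at least 3.3-fold lower number from compound 1 to compound 3 (0.52 log units; beyond the scatter) is expected to run toward stronger inhibition of growth and to lie beyond the scatter, with compound 1 standing at the limit (the limit of > 10000 nM in this assay, at which 1 of the 2 values shown sits). Compound 3 is estimated at 3000 nM, with an expected range from 800 nM to 10000 nM. A reported limit rather than a number remains possible for compound 3.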

Compound 3, concentration for 50% growth inhibition: > 10000 nM
Compound 3: a limit, no number; the forecaster's own chance of this, stated with the estimate: 35%; middle value at least 3.3-fold (0.52 log units) away from the limit.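

In this assay, among the compounds shown here, compound 1 and compound 3 both give a limit of the assay and not a number, so no step between them can be read: the limit of > 10000 nM in this assay, at which 2 of the 3 values shown sit. The compounds shown leave open whether (2-(dimethylamino)ethyl)((prop-1-en-1-yl)carbonyl)amino in place of propanoylamino changes growth inhibition at all.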